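A few compounds are considered here, and "the series" means these few. Any claim that something is new, unique, unknown or untested is made for them only; others in the source may bear on it.

Compound 1 `Cc1ccc(NC2=CC(=O)c3c(nc4n3[C@H]3OC[C@@H](O)[C@H]3OC4)C2=O)cc1C`: 4320 nM
Compound 2 `O=C1C(NC2CC2)=CC(=O)c2c1nc1n2[C@H]2OC[C@@H](O)[C@H]2OC1`: > 16000 nM (a limit)

Both values come from a functional assay on HeLa cells (Homo sapiens) for inhibition, read by sulforhodamine B assay; on this read-out lower numbers stand for stronger inhibition and higher numbers for weaker inhibition. Compound 2 stands at the limit of > 16000 nM in this assay, at which 1 of the 2 values shown sits, so its value is a limit and not a number.

Compound 3 `CCCN(CCC)C1=CC(=O)c2c(nc3n2[C@H]2OC[C@@H](O)[C@H]2OC3)C1=O` changes the amine of compound 2: dipropylamino in place of cyclopropylamino on a double-bonded ring carbon. Among the compounds with values here, no measured compound carries dipropylamino. Within the data shown here, only one measured step bears on this change, the replacement of the group on the amine nitrogen in an at least 3.7-fold higher number from compound 1 to compound 2 (0.56 log units; beyond the scatter), and its size is bounded on one side only. Compound 3 also has no 3,4-dimethylphenyl, so it is expected to stay in the weak range, close to the limit, and it may be reported only as a limit.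

The expected step is an at least 1.0-fold lower number from compound 2 to compound 3 (0.02 log units; that floor lies within the scatter), with no clear change beyond the scatter anticipated. For compound 3 the estimate is 15000 nM, with an expected range of 6000 nM to 40000 nM.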

Compound 3, half-maximal inhibitory concentration: > 16000 nM
Compound 3 ended at the assay's limit; the forecaster's own chance of this, stated with the estimate: 50%; at least 1.0-fold (0.02 log units) between middle value and limit.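

In this assay compound 3 gives > 16000 nM, which is a limit and not a number. With dipropylamino in place of (3,4-dimethylphenyl)amino, the data show an at least 3.7-fold higher number from compound 1 to compound 3 (0.56 log units; beyond the scatter), so this double-bonded ring carbon now has two non-aryl amines on the weak side of compound 1, one with a hydrogen-bond donor in compound 2 and one without in compound 3. The step from compound 2 to compound 3 cannot be read, because both compounds sit at the same limit: the limit of > 16000 nM in this assay, at which 2 of the 3 values shown sit.

From the compounds shown here alone, how far compound 2 and compound 3 lie beyond that limit remains open. Also open, going by these compounds, is whether the activity of compound 1 needs the two methyl groups or only an aryl amine, a question that plain anilino or benzylamino at this carbon would address.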